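Triazole aryl swap on the spiro nitrile series

The source may hold more compounds than are shown below. What is called first, only, known or untested is meant among the compounds shown, and "the series" means these compounds.

Among the measured compounds shown here, compound 2 `CCc1ccccc1-n1nncc1CN1C(=O)C2(C(C#N)=C(N)Oc3c(N)cc4nc5ccccc5nc4c32)c2ccccc21` is the only member with a number in a functional assay on HepG2 cells (Homo sapiens) for antiproliferative activity, read by MTT assay, with a stated time of 48 h (a lower number here means a stronger inhibitor, a higher number a weaker inhibitor), where compound 2 gives 17900 nM. Compound 1 `Cc1ccc(C)c(-n2nncc2CN2C(=O)C3(C(C#N)=C(N)Oc4c3c3nc5ccccc5nc3c3ccccc43)c3ccccc32)c1` reaches only a limit there, > 50000 nM, which is the limit of > 50000 nM in this assay, at which 1 of the 2 values shown sits, rather than a measured value. Compound 3 `N#CC1=C(N)Oc2c(N)cc3nc4ccccc4nc3c2C12C(=O)N(Cc1cnnn1-c1cccc(C(F)(F)F)c1)c1ccccc12` carries 3-(trifluoromethyl)phenyl in place of 2-ethylphenyl on an aromatic nitrogen, a 3-(trifluoromethyl)phenyl in place of 2-ethylphenyl on an aromatic nitrogen. For the measured compounds named here, no step between measured compounds on such an aryl exchange is known, so no change beyond the usual scatter is expected. Compound 3 is accordingly estimated at 20000 nM in this assay, within 6000 nM to 60000 nM, a step of a 1.1-fold higher number from compound 2 to compound 3 (0.05 log units; within the scatter) of essentially none.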

Compound 3, half-maximal inhibitory concentration: 15800 nM
For compound 3 the middle estimate is 1.3-fold (0.10 log units) above the measured one; the range from low to high includes it.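

In this assay, among the compounds shown here, this is the first step that can be read at this position: 3-(trifluoromethyl)phenyl in place of 2-ethylphenyl on the aromatic nitrogen gives a 1.1-fold lower number from compound 2 to compound 3 (0.05 log units; within the scatter). The two aryl groups are therefore not distinguished here, despite their different substituents and substitution patterns. Nothing available offers a reason for this outcome.

Compound 1 differs from compound 2 in more than one place, so steps involving it cannot be read. From the compounds shown here alone, whether an aryl group carrying an amine or a carboxylic acid would move the number beyond the scatter remains open.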